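The source may hold more compounds than are shown below. What is called first, only, known or untested is meant among the compounds shown, and "the series" means these compounds.

Measured compounds:
compound 1, `Cc1ccc(-c2cs/c(=N/NC(=O)CSc3nnnn3-c3ccccc3)n2-c2ccccc2)cc1`, 22.2%
compound 2, `O=C(CSc1nnnn1-c1ccccc1)N/N=c1/scc(-c2ccc(Cl)cc2)n1-c1ccccc1`, 52.4%
compound 3, `O=C(CSc1ncccn1)N/N=c1/scc(-c2ccc(Cl)cc2)n1-c1ccccc1`, 39.7%

These three compounds were compared in a functional assay on C6 cells (Rattus norvegicus) for cytotoxicity, read by MTT assay, with a stated time of 24 h, tested at 200 ug/mL; a higher number here means a weaker effect of the compound at the concentration tested, a lower number a stronger effect. Compound 2 and compound 1 share one core and differ only by methyl in place of chloro on an aromatic carbon; that change gave a number 30.2 percentage points lower from compound 2 to compound 1 (beyond the scatter). Compound 3 carries a different core, and how the two cores differ is pyrimidin-2-yl in place of 1-phenyl-1H-tetrazol-5-yl on a sulfur, a change that gave a number 12.7 percentage points lower from compound 2 to compound 3 (beyond the scatter). Compound 4, `Cc1ccc(-c2cs/c(=N/NC(=O)CSc3ncccn3)n2-c2ccccc2)cc1`, is not yet measured; it differs from compound 3 by methyl in place of chloro on an aromatic carbon, at the same place as before, so this is the same change made on the other core. For the measured compounds named here, for compound 4 the step is expected to be a number 25.7 percentage points lower from compound 3 to compound 4 (beyond the scatter), resting on the earlier step of a number 30.2 percentage points lower from compound 2 to compound 1 (beyond the scatter), though with only one precedent and a different core the size is uncertain. Compound 4 is thus estimated at 14%, between 4% and 30%.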

Compound 4, a percentage reported as activity, at one concentration (the size of the read-out at that concentration, not a potency): 43.7%
Compound 4: middle estimate off by 29.7 percentage points, on the low side; measured number outside the range, above it.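

In this assay, methyl in place of chloro on the core of compound 3 gave a number 4 percentage points higher from compound 3 to compound 4 (within the scatter), so the large step seen on the other core did not recur: the same change on two cores in this assay, a number 30.2 percentage points lower (beyond the scatter) from compound 2 to compound 1 and a number 4 percentage points higher (within the scatter) from compound 3 to compound 4, 34.2 percentage points apart, beyond the scatter of two such steps Pyrimidin-2-yl in place of 1-phenyl-1H-tetrazol-5-yl gave a number 21.5 percentage points higher from compound 1 to compound 4 (beyond the scatter), reversing the direction seen with the chloro group: the same change on two cores in this assay, a number 12.7 percentage points lower (beyond the scatter) from compound 2 to compound 3 and a number 21.5 percentage points higher (beyond the scatter) from compound 1 to compound 4, 34.2 percentage points apart, beyond the scatter of two such steps Neither change can therefore be carried from one core to the other in this series, though four compounds at one concentration do not show why the steps differ or how either change would behave on a further core.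

The compounds shown leave open what an amine or a carboxylic acid on that aromatic carbon would give. They also leave open the result of a longer alkyl chain on the sulfur in place of either ring.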